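A few compounds are considered here, and "the series" means these few. Any claim that something is new, unique, unknown or untested is made for them only; others in the source may bear on it.

Compound 1 `O=C(Nc1cccc(-n2cc(-c3ccncc3)c(-c3ccc(Cl)c(O)c3)n2)c1)Nc1cccc(C(F)(F)F)c1` carries a urea joining two aryl groups, one of which bears the shared core. In a functional assay on HCT-15 cells (Homo sapiens) for inhibition, read by sulforhodamine B assay, with a stated time of 48 h (a higher number here means that more compound is tolerated, a lower number that less compound is tolerated), compound 1 gives > 32500 nM, and this is a limit of the assay rather than a measured number. Compound 2 `O=C(Nc1cccc(-n2cc(-c3ccncc3)c(-c3ccc(Cl)c(O)c3)n2)c1)Nc1ccc(Cl)c(Cl)c1` differs from it by 3,4-dichlorophenyl in place of 3-(trifluoromethyl)phenyl on an amide-type nitrogen. In this assay compound 2 gives > 32500 nM, again a limit. The step that the two limits leave unreadable from compound 1 to compound 2 therefore cannot be read in size or direction. Compound 3 `COc1cc(-c2nn(-c3cccc(NC(=O)Nc4ccc(Cl)c(C(F)(F)F)c4)c3)cc2-c2ccncc2)ccc1Cl` carries a methoxy group on the aromatic ring where compounds 1 and 2 carry hydroxy. In this assay compound 3 gives > 32500 nM, which is also a limit, so compound 3 stands with the other two at the limit: the limit of > 32500 nM in this assay, at which 3 of the 3 values shown sit. Compound 4 `O=C(Nc1cccc(-n2cc(-c3ccncc3)c(-c3ccc(Cl)c(O)c3)n2)c1)Nc1ccc(Cl)c(C(F)(F)F)c1` has not yet been measured; it differs from compound 3 by hydrogen in place of methyl on an oxygen on an aromatic ring. For the measured compounds named here, no measured step bears directly on this change, and the only measured step at all is unreadable. Compounds 1 and 2 already carry the hydroxy group that compound 4 gains, and both sit at the limit. The expected step is a step that the limit leaves unreadable from compound 3 to compound 4, nothing beyond the scatter. Compound 4 is therefore expected to give 45000 nM in this assay, within 20000 nM to 120000 nM, most likely reported again only as a limit.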

Compound 4, concentration lethal to 50% of the cells: > 32500 nM
Compound 4 was reported as a limit (the forecaster's own chance of this, stated with the estimate: 85%); the middle value is on the limit's open side.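

In this assay compound 4 gives > 32500 nM, which is a limit of the assay. Its steps from compound 1, compound 2 and compound 3 therefore cannot be read in size or direction: the limit of > 32500 nM in this assay, at which 4 of the 4 values shown sit.

The compounds shown leave open whether any of these changes, methoxy to hydroxy included, alters the lethal concentration at all.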